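The compounds below may be only part of what the source reports. "The series", "measured", "known", "first", "only" and "open" are said of these compounds alone.

Compound 1, `COc1ccc(OCc2nc(N)nc(Nc3ccc(C)c(Cl)c3)n2)cc1N1CCCC1=O`, and compound 2, `Cc1ccc(Nc2nc(N)nc(COc3cc(N4CCCC4=O)ccc3F)n2)cc1Cl`, share a core with an amino-triazine bearing an anilino group and an aryloxymethyl arm. In an assay on COS-7 cells for agonist activity at Free fatty acid receptor 1 (Homo sapiens), read by scintillation counting and inositol phosphate accumulation, with a stated time of 90 min (a lower number here means that less compound is needed, a higher number that more compound is needed for the effect), compound 1 gives 20200 nM, and in this assay compound 2 gives 33100 nM; both numbers sit far up the concentration range. From the compounds shown here alone, compound 3, `Cc1ccc(Nc2nc(N)nc(COc3cc(N4CCCC4=O)ccc3Cl)n2)cc1Cl`, carries a chloro group where compound 2 carries fluoro, yet for compound 3 this assay yields "not determined" (no result reported) and so no single number, so its standing among the measured compounds is unknown. Compound 4, `Cc1ccc(Nc2nc(N)nc(COc3cc(N4CCCC4=O)ccc3C(F)(F)F)n2)cc1Cl`, differs from compound 3 by trifluoromethyl in place of chloro on an aromatic carbon. For the measured compounds named here, with no step between measured compounds available, the only anchors are the weak values of compound 1 and compound 2; any step from compound 3 to compound 4 in this assay is expected to stay within the scatter, in no clear direction. On that basis compound 4 is estimated to give about 28000 nM in this assay, with a range from 8000 nM to 90000 nM.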

Compound 4, half-maximal effective concentration: 20100 nM
Beside the measured number, compound 4's estimate is 1.4-fold (0.14 log units) above it; low and high end bracket the measured number.
By their numbers in this assay, from the lowest: compounds 4, 1 and 2 (each within the scatter of the next).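

In this assay, for the compounds shown here, trifluoromethyl in place of fluoro on this aromatic carbon, para to the 2-oxopyrrolidin-1-yl group, gives a 1.6-fold lower number from compound 2 to compound 4 (0.22 log units; within the scatter), the first single-place comparison at this position, and it shows that these two groups cannot be told apart here. The step from compound 3 to compound 4 cannot be read, as compound 3 has no number, so chloro remains unplaced relative to both groups. No supporting data bear on this result.

The compounds shown leave open whether any group at this position could move the number beyond the scatter, since both readings here stay far up the concentration range. An amine or a carboxylic acid on this carbon might answer that, but neither appears among these compounds.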